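A few compounds are considered here, and "the series" means these few. Any claim that something is new, unique, unknown or untested is made for them only; others in the source may bear on it.

Measured in a functional assay on DU-145 cells (Homo sapiens) for cytotoxicity, read by MTT assay; a lower number here means a stronger inhibitor, a higher number a weaker inhibitor:
- compound 1 `CC(C)=CC[C@@H](OC(=O)c1ccco1)C1=CC(=O)c2c(O)ccc(O)c2C1=O`: > 100000 nM
- compound 2 `CC[C@](C)(O)CC(=O)O[C@H](CC=C(C)C)C1=CC(=O)c2c(O)ccc(O)c2C1=O`: 20500 nM
- compound 3 `CC(C)=CC[C@@H](OC(=O)CC(C)(O)c1ccccc1)C1=CC(=O)c2c(O)ccc(O)c2C1=O`: > 100000 nM

Compound 1 carries only a limit of the assay. Compound 3 likewise carries only a limit, and it stands at the limit of > 100000 nM in this assay, at which 2 of the 3 values shown sit. Compound 2 alone has a true number.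

Compound 4 `CCCCC(C)(O)CC(=O)O[C@H](CC=C(C)C)C1=CC(=O)c2c(O)ccc(O)c2C1=O` differs from compound 3 by one change: butyl in place of phenyl on a saturated chain carbon bound to an oxygen on a saturated carbon and two saturated chain carbons. Butyl thus takes the place of phenyl on a saturated chain carbon.

The nearest evidence is an at least 4.8-fold higher number from compound 2 to compound 3 (0.68 log units; beyond the scatter), where 1-hydroxy-1-phenylethyl replaced 1-hydroxy-1-methylpropyl. Compound 4 has no phenyl there, and its 1-hydroxy-1-methylpentyl resembles the group of compound 2. The step of an at least 4.8-fold lower number from compound 1 to compound 2 (0.68 log units; beyond the scatter) also shows that this kind of group gave a readable number, while a step that the two limits leave unreadable from compound 1 to compound 3 offers nothing to size.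

A reversal of the step seen with compound 3 is therefore expected in this assay, towards a lower number. The expected step is an at least 6.6-fold lower number from compound 3 to compound 4 (0.82 log units; beyond the scatter).

Compound 4 is estimated at 15000 nM, with an expected range of 5000 nM to 50000 nM.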

Compound 4, half-maximal inhibitory concentration: 76500 nM
Compound 4: the middle estimate sits 5.1-fold (0.71 log units) below what was measured; the whole stated range lies below it.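

In this assay, butyl in place of phenyl on this saturated chain carbon gives a true number, yet this reads only as an at least 1.3-fold lower number from compound 3 to compound 4 (0.11 log units; that floor lies within the scatter), and an at least 1.3-fold lower number from compound 1 to compound 4 (0.11 log units; that floor lies within the scatter) is likewise no more than a floor. These steps stay floors because compound 1 and compound 3 each carry only a limit of the assay: the limit of > 100000 nM in this assay, at which 2 of the 4 values shown sit. What is new is that removing phenyl does not by itself recover the number of compound 2, since 1-hydroxy-1-methylpentyl in place of 1-hydroxy-1-methylpropyl gives a 3.7-fold higher number from compound 2 to compound 4 (0.57 log units; beyond the scatter).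

From the compounds shown here alone, with only these two chains, it stays open whether a propyl chain at this place would fall nearer to compound 2 or to compound 4. Going by these compounds, it is also open whether a cyclohexyl ring here would behave like phenyl or like butyl.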